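From Acylated Amine to Free Amine: an Expected Cytotoxicity

The compounds below may be only part of what the source reports. "The series", "measured", "known", "first", "only" and "open" are said of these compounds alone.

Three compounds have been measured in a toxicity assay on KB cells (Homo sapiens) for cytotoxicity, read by fluorescence, with a stated time of 3 days; a lower number here means that less compound is needed, a higher number that more compound is needed for the effect:

Compound 1, `CCCCOC(=O)CNC(=O)[C@H](CSc1ccc([N+](=O)[O-])cc1[N+](=O)[O-])NC(=O)CC[C@H](NC(=O)CC(C)C)C(=O)OCCCC`: 59.6 uM
Compound 2, `CCCCOC(=O)CNC(=O)[C@H](CSc1ccc([N+](=O)[O-])cc1[N+](=O)[O-])NC(=O)CC[C@H](NC(=O)OC(C)(C)C)C(=O)OCCCC`: 70.4 uM
Compound 3, `CCCCOC(=O)CNC(=O)[C@H](CSc1ccc([N+](=O)[O-])cc1[N+](=O)[O-])NC(=O)CC[C@H](NC(=O)CCc1ccccc1)C(=O)OCCCC`: > 300 uM, which is a limit of the assay rather than a number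

Compound 1 holds the lowest of the two numbers shown. Compound 2 sits close to it: a 1.2-fold higher number from compound 1 to compound 2 (0.07 log units; within the scatter), a change that stays within the scatter. Compound 3 reached only the limit (the limit of > 300 uM in this assay, at which 1 of the 3 values shown sits). The steps to it are larger: an at least 5.0-fold higher number from compound 1 to compound 3 (0.70 log units; beyond the scatter) and an at least 4.2-fold higher number from compound 2 to compound 3 (0.62 log units; beyond the scatter), both beyond the scatter.

Compound 4 is `CCCCOC(=O)CNC(=O)[C@H](CSc1ccc([N+](=O)[O-])cc1[N+](=O)[O-])NC(=O)CC[C@H](N)C(=O)OCCCC`. Against compound 1 the change is hydrogen in place of isobutylcarbonyl on an amine nitrogen. All three measured steps alter the group on this same amine nitrogen: swapping one small acyl for another left the number unchanged within the scatter, while the step to a phenethyl cap pushed compound 3 to the limit. None of them removes the cap altogether, so the measured steps give only a loose guide. The expectation for compound 4 is a step of a 1.3-fold higher number from compound 1 to compound 4 (0.13 log units; within the scatter), within or just beyond the scatter, and the estimated value for compound 4 in this assay is 80 uM, with a range from 30 uM to 250 uM.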

Compound 4, concentration for half-maximal effect: 107 uM
Compound 4: the middle estimate sits 1.3-fold (0.13 log units) below what was measured; low and high end bracket the measured number.
By their numbers in this assay, from the lowest: compounds 1, 2 and 4 (each within the scatter of the next). At a limit, above all of these: compound 3.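

In this assay the full removal of the cap from the amine nitrogen gives a 1.8-fold higher number from compound 1 to compound 4 (0.25 log units; within the scatter) and also a 1.5-fold higher number from compound 2 to compound 4 (0.18 log units; within the scatter) and so neither isobutylcarbonyl nor tert-butoxycarbonyl is required for a number in this range. Removing phenethylcarbonyl from the same nitrogen gives an at least 2.8-fold lower number from compound 3 to compound 4 (0.44 log units; beyond the scatter) and so the high reading of compound 3 goes with that one cap and not with capping of this nitrogen as such, as compound 1 and compound 2 also show. The reading for compound 3 is a limit of the assay and not a number: the limit of > 300 uM in this assay, at which 1 of the 4 values shown sits.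

Still open, from the compounds shown here alone, is whether a small acetyl cap or a longer straight alkyl chain on this nitrogen would stay with compound 1, compound 2 and compound 4 or move towards compound 3, and whether the phenyl ring or the length of the chain in phenethylcarbonyl goes with the step. The butyl esters also stay the same throughout, so the compounds shown leave open what a free carboxylic acid in their place would do in this assay.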